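The source may report more compounds than this note shows. Statements on the series, on what has been measured and on what is new or still open speak of the compounds shown alone.

Compound 3 `CCCCNc1cccc(NC(=O)c2ccc(OCCC)cc2)n1` is one of three compounds examined in an in vitro assay on HEK-tsA201 cells for antagonist activity at Neuronal acetylcholine receptor; alpha3/beta4 (Homo sapiens), read by fluorescence and calcium flux; on this read-out higher numbers stand for weaker inhibition and lower numbers for stronger inhibition. Compound 1 `C=CCOc1ccc(C(=O)Nc2ccccn2)cc1` gives 61400 nM in this assay. Compound 2 `C=CCOc1ccc(C(=O)Nc2cccc(Cl)n2)cc1` reaches a limit of this assay at > 100000 nM, a limit rather than a number. Compound 3 gives 77800 nM in this assay, the higher of the two numbers, though its gap to compound 1 lies within the scatter. Among the measured compounds shown here, the single step between measured compounds that differ in one place is an at least 1.6-fold higher number from compound 1 to compound 2 (0.21 log units; that floor lies within the scatter), the exchange of a hydrogen on an aromatic carbon for a chloro group on the shared core. That step ends at the limit of > 100000 nM in this assay, at which 1 of the 3 values shown sits, so its true size is not known.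

Compound 4 `C=CCOc1ccc(C(=O)Nc2cccc(NCCCC)n2)cc1` differs from compound 3 in one place: vinyl in place of ethyl on a saturated chain carbon bound to an oxygen on an aromatic ring. For the measured compounds named here, no measured step changes this chain on the oxygen, and the step from compound 1 to compound 2 concerns a different part of the molecule, so nothing among the measured compounds points to a shift in either direction beyond the scatter. The step of a 1.0-fold lower number from compound 3 to compound 4 (0.02 log units; within the scatter) that this estimate means is expected to be small. Compound 4 is estimated at 75000 nM, within a range from 30000 nM to 150000 nM, with a real chance that this assay again reports only a limit.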

Compound 4, half-maximal inhibitory concentration: 19200 nM
Estimate against measurement, compound 4: 3.9-fold (0.59 log units) above, outside the stated range (below it).
By their numbers in this assay, from the lowest: compound 4; then compounds 1 and 3 (each within the scatter of the next). At a limit, above all of these: compound 2.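

In this assay, among the compounds shown here, the exchange of propoxy for allyloxy is the first measured change to the chain on the oxygen, and it gives a 4.1-fold lower number from compound 3 to compound 4 (0.61 log units; beyond the scatter), so a single double bond outside the aromatic rings, with the count of heavy atoms unchanged, moves the read-out beyond the scatter. With allyloxy held in place, the other aromatic position also proves responsive: butylamino in place of hydrogen gives a 3.2-fold lower number from compound 1 to compound 4 (0.50 log units; beyond the scatter), and butylamino in place of chloro gives an at least 5.2-fold lower number from compound 2 to compound 4 (0.71 log units; beyond the scatter). That second step is only a floor, since compound 2 stands at a limit of the assay and not at a number: the limit of > 100000 nM in this assay, at which 1 of the 4 values shown sits.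

The compounds shown leave open whether the step from propoxy to allyloxy would also appear in the absence of butylamino, and whether it belongs to the double bond itself or would extend to a triple bond as in propargyloxy or to a longer chain such as butoxy. They also leave open how a shorter amine such as propylamino, a longer one such as hexylamino, or a cyclic amine such as piperidine would compare with butylamino at this place.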